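The source may hold more compounds than are shown below. What is called first, only, known or untested is meant among the compounds shown, and "the series" means these compounds.

Measured compounds in an ADME assay on cells (Hepatocyte, Homo sapiens) for metabolic stability, read by LC-MS, with a stated time of 60 min, tested at 1 uM; a higher number here means faster removal of the compound, a lower number slower removal:

- compound 1 `COc1cc(N(CC2CC2)c2ccc(F)c3ccccc23)cnc1C(=O)[C@H]1C[C@@H]1C(=O)O`: 5.4 uL/min
- compound 2 `COc1cc(N(CC(C)C)c2ccc(F)c3ccccc23)cnc1C(=O)[C@H]1C[C@@H]1C(=O)O`: 56 uL/min
- compound 3 `COc1cc(N(CC2CC2)c2cc(C(F)(F)F)ccc2F)cnc1C(=O)[C@H]1C[C@@H]1C(=O)O`: < 1.1 uL/min

The value of compound 3 is a limit of this assay and not a number, namely (the limit of < 1.1 uL/min in this assay, at which 1 of the 3 values shown sits). Between compound 1 and compound 2 the change is isopropyl in place of cyclopropyl on a saturated chain carbon bound to a nitrogen on an aromatic ring, and it gave a 10-fold higher number from compound 1 to compound 2 (1.02 log units; beyond the scatter). The difference between the core of compound 1 and the core of compound 3 is not broken down here.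

Compound 4 `COc1cc(N(CC(C)C)c2cc(C(F)(F)F)ccc2F)cnc1C(=O)[C@H]1C[C@@H]1C(=O)O` is not yet measured in this assay. It differs from compound 3 by isopropyl in place of cyclopropyl on a saturated chain carbon bound to a nitrogen on an aromatic ring, the same change at the same place as that from compound 1 to compound 2. The step expected from compound 3 to compound 4 is an at least 3.6-fold higher number from compound 3 to compound 4 (0.56 log units; beyond the scatter), resting on the measured step of a 10-fold higher number from compound 1 to compound 2 (1.02 log units; beyond the scatter), with the reservation that compound 3 provides only a limit as the starting point. For compound 4 in this assay the estimate is 4 uL/min, with the range 1.1 uL/min to 15 uL/min.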

Compound 4, intrinsic clearance in a liver preparation (reported as CLH), per the amount of preparation that the assay uses in the Hepatocyte assay: 3.9 uL/min
Estimate against measurement, compound 4: 1.0-fold (0.01 log units) above, and the stated range covers the measured number.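

In the Hepatocyte assay isopropyl in place of cyclopropyl on the second core gave an at least 3.5-fold higher number from compound 3 to compound 4 (0.54 log units; beyond the scatter) and so the number rises on both cores shown. In a physicochemical assay for lipophilicity, read by LC-MS, in phosphate buffer, measured as octanol-water partition, at pH 7.4 (a lower number here means a more polar compound, a higher number a more lipophilic compound), compound 3 gives 1.2 and compound 4 gives 1.4 with a number 0.20 log units higher from compound 3 to compound 4 (within the scatter) on this pair. In the Hepatocyte assay the value of compound 3 is a limit and not a number, so the change carries over in direction, while its size on the two cores cannot be compared: the same change on two cores in the Hepatocyte assay, a 10-fold higher number (1.02 log units; beyond the scatter) from compound 1 to compound 2 and an at least 3.5-fold higher number (0.54 log units; beyond the scatter) from compound 3 to compound 4; the limit leaves it open whether they differ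

For the compounds shown here, only two cores carry this change, so its behaviour on any other core stays open. Also open, as far as these compounds go, is how the Hepatocyte assay would read for a cyclobutyl group or a longer chain at this place.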